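Adding a second bromo to compound 1

The source may report more compounds than this note shows. Statements on the series, on what has been measured and on what is new or still open speak of the compounds shown alone.

Compound 1 `OCc1cn(Cc2cccc(Br)c2)c2ccccc12`: 28 nM
Compound 2 `OCc1cn(Cc2cccc(I)c2)c2ccccc12`: 100 nM
Compound 3 `OCc1cn(Cc2cccc(C(F)(F)F)c2)c2ccccc12`: 39 nM
Compound 4 `OCc1cn(Cc2ccc(Br)c(Br)c2)c2ccccc12`: not yet measured

In a functional assay on NCI-H460 cells (Homo sapiens) for cytotoxicity, read by sulforhodamine B assay, with a stated time of 3 days (a lower number here means a stronger inhibitor, a higher number a weaker inhibitor), compound 1 gives 28 nM and sits at the low end of the numbers together with compound 3, since the data show a 1.4-fold higher number from compound 1 to compound 3 (0.14 log units; within the scatter). Compound 2 stands higher, with a 3.6-fold higher number from compound 1 to compound 2 (0.55 log units; beyond the scatter).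

The change to compound 4 is bromo in place of hydrogen on an aromatic carbon, ortho to a bromo group and para to a large group. Within the data shown here, no measured step adds a group in this way. The known steps only exchange one group for another, so they are a loose guide. Still, they show that such exchanges can move the number modestly, as in a 2.6-fold lower number from compound 2 to compound 3 (0.41 log units; beyond the scatter). Among the measured compounds shown here, the step to compound 2, a 3.6-fold higher number from compound 1 to compound 2 (0.55 log units; beyond the scatter), is the only guide to a rise from compound 1, so a modest rise in this assay is expected, though no change beyond the scatter remains possible.

The expected step is a 2.1-fold higher number from compound 1 to compound 4 (0.33 log units; beyond the scatter). Compound 4 is estimated at 60 nM, with an expected range from 20 nM to 180 nM.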

Compound 4, half-maximal inhibitory concentration: 50 nM
Compound 4: middle estimate off by 1.2-fold (0.08 log units), on the high side; measured number inside the range.
By their numbers in this assay, from the lowest: compounds 1, 3, 4 and 2 (each within the scatter of the next, the first and the last beyond it).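

Compounds 1, 2 and 3 only exchange one group for another at a single place, so they say nothing about adding a group to a carbon that carries hydrogen. In this assay, putting bromo in place of hydrogen, ortho to a bromo group and para to a large group, gives a 1.8-fold higher number from compound 1 to compound 4 (0.25 log units; within the scatter), so a second halogen atom on this ring leaves the number within what repeated measurements would show. Among the compounds shown, this carbon therefore accepts a bromo without a clear loss, although no measurement here explains why.

On these data alone, whether an amine, a carboxylic acid or a methoxy group on the same carbon would behave in the same way remains open. So does whether this new bromo would give a similar number without the existing bromo group on the ring.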